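Anilide pair: ethoxy in place of fluoro on the aryl ring

The source may report more compounds than this note shows. Statements on the series, on what has been measured and on what is new or still open speak of the compounds shown alone.

Measured in a functional assay (QGY7701 cells, Homo sapiens) for inhibition, read by MTT assay, with a stated time of 48 h; on this read-out higher numbers stand for weaker inhibition and lower numbers for stronger inhibition: compound 1 `COc1ccc2c(=O)c(/C=C/C(=O)NCc3ccc(F)cc3)coc2c1` gives 7960 nM. Compound 2 `COc1ccc2c(=O)c(/C=C/C(=O)Nc3ccc(F)cc3)coc2c1` reports only an assay limit, > 100000 nM.

Compound 2 therefore stands at the limit, where one of the two values sits (the limit of > 100000 nM in this assay, at which 1 of the 2 values shown sits). Going by the values given here, the single measured step, an at least 12-fold higher number from compound 1 to compound 2 (1.09 log units; beyond the scatter), changes the nitrogen substituent, not the aryl substituent, so it bears only indirectly here. Compound 3 `CCOc1ccc(NC(=O)/C=C/c2coc3cc(OC)ccc3c2=O)cc1` keeps the anilide of compound 2 and differs by ethoxy in place of fluoro on an aromatic carbon. Among the compounds with values here, no measured step covers this change. Compound 3 is expected to remain near the limit, an at least 1.1-fold lower number from compound 2 to compound 3 (0.04 log units; that floor lies within the scatter), estimated at 90000 nM (range 20000 nM to 300000 nM). This expectation rests on compound 2 standing at the limit > 100000 nM.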

Compound 3, half-maximal inhibitory concentration: > 100000 nM
Compound 3 was reported as a limit (the forecaster's own chance of this, stated with the estimate: 60%); middle value at least 1.1-fold (0.04 log units) away from the limit.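

In this assay, compound 3 gives > 100000 nM, which is a limit, so a second anilide substituent also gives no value inside the assay range. 4-Ethoxyphenyl in place of 4-fluorobenzyl on the amide-type nitrogen gives an at least 12-fold higher number from compound 1 to compound 3 (1.09 log units; beyond the scatter), a large step that matches the one seen with 4-fluorophenyl. Because both anilides stand at a limit, the step between them cannot be read: the limit of > 100000 nM in this assay, at which 2 of the 3 values shown sit.

Going by these compounds, whether 4-ethoxybenzyl on the nitrogen would behave like the 4-fluorobenzyl of compound 1 remains open. So does whether an amine or a carboxylic acid in place of ethoxy would bring an anilide back within the assay range.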